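The source may report more compounds than this note shows. Statements on the series, on what has been measured and on what is new or still open speak of the compounds shown alone.

Measured in a functional assay on MDA-MB-231 cells (Homo sapiens), read by microscopy and transwell migration, with a stated time of 24 h; a higher number here means a weaker inhibitor, a lower number a stronger inhibitor:
- Compound 1 `Cc1ccc(-c2csc(N(C)S(=O)(=O)c3ccccc3)n2)c(C)c1`: > 25000 nM
- Compound 2 `Cc1sc(NC(=O)c2ccccc2)nc1-c1ccccc1`: > 25000 nM
- Compound 3 `COc1cc(-c2csc(NC(=O)c3ccc(Cl)cc3)n2)cc(OC)c1OC`: > 25000 nM

Each of these entries is a limit of the assay and not a number, so none of the three compounds has a measured half-maximal inhibitory concentration. Compound 3 therefore stands at a shared limit, and the series offers no ranking: the limit of > 25000 nM in this assay, at which 3 of the 3 values shown sit.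

Compound 4 `COc1ccccc1C(=O)Nc1nc(-c2cc(OC)c(OC)c(OC)c2)cs1` keeps the rest of compound 3 and carries 2-methoxyphenyl in place of 4-chlorophenyl on a carbonyl carbon. Within the data shown here, no two measured compounds differ in only one place, so no measured step shows what a change of this kind does in this assay. Without such a guide, no shift beyond the usual scatter is expected, and neither direction is favoured. The estimated step, a number no higher from compound 3 to compound 4 (the limit leaves the size open), is only a rough expectation. For compound 4, the expected value is 25000 nM. The estimated range for compound 4 runs from 8000 nM to 50000 nM.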

Compound 4, half-maximal inhibitory concentration: 8500 nM
Compound 4: the middle estimate sits 2.9-fold (0.47 log units) above what was measured; measured number inside the range.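

In this assay, the carbonyl carbon is the first place among the compounds shown where a change moves the read-out: 2-methoxyphenyl in place of 4-chlorophenyl gives an at least 2.9-fold lower number from compound 3 to compound 4 (0.46 log units; beyond the scatter). Compound 3 has > 25000 nM, which is a limit of the assay and not a number. Compound 4 is therefore the only compound here with a measured number, and it now stands apart from the others: the limit of > 25000 nM in this assay, at which 3 of the 4 values shown sit.

The two groups differ in both their substituent and where it sits, so this single swap cannot say which of these matters, or whether losing the chlorine or gaining the methoxy counts more. It also leaves open how a 2-ethoxyphenyl group, or a phenyl ring carrying an amine, would behave on the same carbonyl carbon in this assay.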